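A carboxylic acid in place of an alcohol on a side chain

The source may hold more compounds than are shown below. What is called first, only, known or untested is meant among the compounds shown, and "the series" means these compounds.

Of the compounds shown here, three with related cores have been tested in a functional assay on MDA-MB-231 cells (Homo sapiens) for inhibition, read by MTT assay, with a stated time of 72 h; a lower number here means a stronger inhibitor, a higher number a weaker inhibitor. Compound 1 `CC(C)=CCC[C@H](C)c1ccc(C)c2c1OCN(CCCCCO)C2` gives 5400 nM. Compound 2 `CC(C)=CCC[C@H](C)c1ccc(C)c(CNCCCCCO)c1O` gives 10700 nM; how its core differs from that of compound 1 is not broken down here. Compound 3 `CC(C)=CCC[C@H](C)c1ccc(C)c2c1OCN(CCCCC(=O)O)C2` gives only a limit of the assay, > 50000 nM. The change from compound 1 to compound 3 is carboxy in place of hydroxymethyl on a saturated chain carbon, four bonds along the chain from an amine nitrogen in a ring. It brought an at least 9.2-fold higher number from compound 1 to compound 3 (0.96 log units; beyond the scatter), and compound 3 sits at the limit of > 50000 nM in this assay, at which 1 of the 3 values shown sits.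

Compound 4 `CC(C)=CCC[C@H](C)c1ccc(C)c(CNCCCCC(=O)O)c1O` has not yet been measured in this assay. It differs from compound 2 by carboxy in place of hydroxymethyl on a saturated chain carbon, four bonds along the chain from an amine nitrogen. This is the same kind of change as that from compound 1 to compound 3, but there the amine nitrogen is in a ring and here it is not. Resting on the value of compound 2, 10700 nM, and on the size of the step from compound 1 to compound 3, a step of about a 7.5-fold higher number from compound 2 to compound 4 (0.87 log units; beyond the scatter) is expected. Compound 4 is therefore estimated at around 80000 nM, probably between 30000 nM and 250000 nM, and may well come out only as a limit of the assay.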

Compound 4, half-maximal inhibitory concentration: > 50000 nM
Compound 4: only a limit was reported (the forecaster's own chance of this, stated with the estimate: 70%); the middle value is on the limit's open side.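

Putting carboxy in place of hydroxymethyl on the chain of compound 2 brought an at least 4.6-fold higher number from compound 2 to compound 4 (0.66 log units; beyond the scatter) in this assay. Compound 4 reads > 50000 nM, which is a limit of the assay and not a number. The weakening seen on the core of compound 1 therefore carries over to the core of compound 2 in direction and, on both cores, goes beyond the scatter, but the true size of each step remains unknown, and so does any difference between them: the same change on two cores in this assay, an at least 9.2-fold higher number (0.96 log units; beyond the scatter) from compound 1 to compound 3 and an at least 4.6-fold higher number (0.66 log units; beyond the scatter) from compound 2 to compound 4; the limit leaves it open whether they differ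

The compounds shown leave open whether this weakening belongs to the carboxy group alone, or whether an amide or a methyl ester at the end of the chain would behave the same way. They also leave open whether a carboxylic acid on a shorter or longer chain would give a value inside the range of the assay, which would let the change be sized as a real number.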